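Ethyl to tert-butyl beside the ketone in a glutamate modulator

The source may hold more compounds than are shown below. What is called first, only, known or untested is meant among the compounds shown, and "the series" means these compounds.

This account follows a series measured in an assay on HEK293 cells for positive allosteric modulation of metabotropic glutamate receptor 3 (Rattus norvegicus), read by thallium flux, with a stated time of 2.5 min; a higher number here means that more compound is needed for the effect, a lower number that less compound is needed. Compound 2 `CCCC(=O)c1ccc(OCCCCOc2cccc(C(=O)O)c2C)c(C)c1O` reaches only the limit > 10000 nM in this assay, a limit and not a number. Compound 1 `Cc1c(OCCCCOc2ccc(C(=O)O)cc2F)ccc(C(=O)CC2CCCC2)c1O` likewise stops at the limit > 10000 nM. For compound 3 `Cc1c(OCCCCOc2ccc(F)c(C(=O)O)c2)ccc(C(=O)CC(C)C)c1C` the outcome is "not determined" (no result reported). So compound 2 stands where two of the three values sit (the limit of > 10000 nM in this assay, at which 2 of the 3 values shown sit), with no numbered value beside it. Compound 4 `Cc1c(OCCCCOc2ccc(C(=O)CC(C)(C)C)c(O)c2C)cccc1C(=O)O` differs from compound 2 by tert-butyl in place of ethyl on a saturated chain carbon bound to a carbonyl carbon. Within the data shown here, no step between measured compounds is known here, and the author expects none beyond the scatter, with the result again most likely a limit. The expected step that the limit leaves unreadable from compound 2 to compound 4 is therefore small, and compound 4 is estimated at 15000 nM, ranging from 3000 nM to 60000 nM.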

Compound 4, half-maximal effective concentration: 300 nM
Compound 4: middle estimate off by 50-fold (1.70 log units), on the high side, and the stated range ends above it.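

In this assay, tert-butyl in place of ethyl on a saturated chain carbon bound to a carbonyl carbon gives an at least 33-fold lower number from compound 2 to compound 4 (1.52 log units; beyond the scatter). Among these compounds, this place therefore responds strongly to the change, which the earlier compounds, with only limits or no result, could not show. The true step may be larger still, because compound 2 gives a limit and not a number: the limit of > 10000 nM in this assay, at which 2 of the 4 values shown sit.

The compounds shown leave open whether a cyclopropyl or trifluoromethyl group in that place would do the same. They also give no cause for the step.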